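The source may hold more compounds than are shown below. What is called first, only, known or untested is meant among the compounds shown, and "the series" means these compounds.

Compound 2 `Nc1nc2cc(-c3nn(CCCCCC(=O)NO)c4ncnc(N)c34)ccc2o1` carries a six-carbon chain ending in a hydroxamic acid on a core shared with compound 4. In a functional assay on HepG2 cells (Homo sapiens) for inhibition, read by MTT assay, with a stated time of 72 h (a higher number here means a weaker inhibitor, a lower number a stronger inhibitor), compound 2 gives 1990 nM, the lowest of the two numbers measured here. Its nearest neighbour on that scale is compound 3 `Nc1ncnc2c1c(-c1cnc3[nH]ccc3c1)nn2CCCCCCC(=O)NO`, which in this assay gives 10300 nM. Compound 1 `Nc1ncnc2c1c(-c1cnc3[nH]ccc3c1)nn2CCCC(=O)NO` carries a shorter chain on the same core as compound 3. In this assay compound 1 reaches only a limit of this assay at > 50000 nM. Among the measured compounds shown here, the one step measured in a single place, an at least 4.8-fold lower number from compound 1 to compound 3 (0.68 log units; beyond the scatter), shows that lengthening the chain by 3-(hydroxycarbamoyl)propyl in place of hydroxycarbamoyl makes the number fall, at least modestly.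

Compound 4 `Nc1nc2cc(-c3nn(CCCCC(=O)NO)c4ncnc(N)c34)ccc2o1` goes the other way from compound 2: hydroxycarbamoyl in place of (hydroxycarbamoyl)methyl on a saturated chain carbon, four bonds along the chain from an aromatic nitrogen. For the measured compounds named here, because the only measured step, an at least 4.8-fold lower number from compound 1 to compound 3 (0.68 log units; beyond the scatter), rewards a longer chain, a chain one carbon shorter is expected to raise the number, though by a smaller amount than that three-carbon step, and on a different core. Compound 4 is therefore expected to give 4000 nM in this assay, between 1500 nM and 12000 nM, which means an expected step of a 2.0-fold higher number from compound 2 to compound 4 (0.30 log units; within the scatter).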

Compound 4, half-maximal inhibitory concentration: 2100 nM
For compound 4 the middle estimate is 1.9-fold (0.28 log units) above the measured one; the range from low to high includes it.
By their numbers in this assay, from the lowest: compounds 2 and 4 (each within the scatter of the next); then compound 3. At a limit, above all of these: compound 1.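

In this assay, the step at this position, a 1.1-fold higher number from compound 2 to compound 4 (0.02 log units; within the scatter), shows that on the core of compound 2 the shorter chain of compound 4 cannot be told apart from the longer one. The dependence on chain length seen on the other core, an at least 4.8-fold lower number from compound 1 to compound 3 (0.68 log units; beyond the scatter), therefore does not carry over to this pair, although that step spans a larger difference in the chain. Nothing shown here gives a reason for this flat result.

On these data alone, what remains open is whether a still shorter or a longer chain on the core of compound 2 would leave the number where it stands. Also open, as far as these compounds go, is what a carboxylic acid or a primary amide in place of the hydroxycarbamoyl end would give on this core.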